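Chloro to methoxy on two cores: antiproliferative notes

A few compounds are considered here, and "the series" means these few. Any claim that something is new, unique, unknown or untested is made for them only; others in the source may bear on it.

Two pairs share a core each. Compound 1 `COc1ccc(-c2nc(C)c(C(=O)CSc3nc(-c4ccc(Cl)cc4)c(C#N)c(=O)[nH]3)s2)cc1` and compound 2 `COc1ccc(-c2nc(C)c(C(=O)CSc3nc(-c4ccc(OC)cc4)c(C#N)c(=O)[nH]3)s2)cc1` form the first pair; compound 3 `Cc1nc(-c2ccc(Cl)cc2)sc1C(=O)CSc1nc(N)c(C#N)c(-c2ccc(Cl)cc2)n1` and the unmeasured compound 4 `COc1ccc(-c2nc(SCC(=O)c3sc(-c4ccc(Cl)cc4)nc3C)nc(N)c2C#N)cc1` form the second. How the core of compound 3 differs from the core of compound 1 is not broken down here.

In a functional assay on U-87MG ATCC cells for antiproliferative activity against U-87 MG (Homo sapiens), read by MTT assay, with a stated time of 48 h, tested at 10 uM (a higher number here means a weaker effect of the compound at the concentration tested, a lower number a stronger effect), compound 1 gives 92.7% and compound 2 gives 80.3%. The step of a number 12.4 percentage points lower from compound 1 to compound 2 (beyond the scatter) goes with the change (methoxy in place of chloro on an aromatic carbon).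

Compound 3 gives 37.3% in this assay, the lowest of the three numbers and beyond the scatter from both others.

The change from compound 3 to compound 4 is methoxy in place of chloro on an aromatic carbon, the same change as in the first pair, at a place described in the same words.

The step of a number 11.3 percentage points lower from compound 3 to compound 4 (beyond the scatter) is expected to be of similar size, because the first pair showed a number 12.4 percentage points lower from compound 1 to compound 2 (beyond the scatter). Within the data shown here, only one earlier instance supports this, on a different core.

Compound 4 is estimated at 26% in this assay, within 8% to 50%.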

Compound 4, a percentage reported as activity, at one concentration (the size of the read-out at that concentration, not a potency): 64.5%
Beside the measured number, compound 4's estimate is 38.5 percentage points below it; measured number above the stated range.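

In this assay, the change from 4-chlorophenyl to 4-methoxyphenyl gives a number 27.2 percentage points higher from compound 3 to compound 4 (beyond the scatter), so on this core the methoxy compound shows the weaker effect at the concentration tested. The change therefore does not carry over as a fixed step from the core of compound 1 to the core of compound 3, and the two steps run in opposite directions: the same change on two cores in this assay, a number 12.4 percentage points lower (beyond the scatter) from compound 1 to compound 2 and a number 27.2 percentage points higher (beyond the scatter) from compound 3 to compound 4, 39.6 percentage points apart, beyond the scatter of two such steps. This shows that a step read on one of these cores cannot be transferred to the other, but with a single pair on each core and cores that differ in more than one place, it does not show which difference between the cores goes with the reversal.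

Open, on these data alone, is how a fluoro or a trifluoromethyl in place of the chloro would read on each core. Also open, as far as these compounds go, is what happens when the remaining 4-chlorophenyl of compound 4 becomes 4-methoxyphenyl, a step that would bring the two cores closer together.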